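Chloro to heteroaryl-sulfanyl exchange on the anilide side chain

The source may hold more compounds than are shown below. What is called first, only, known or untested is meant among the compounds shown, and "the series" means these compounds.

Compound 1 `Cn1c(-c2ccc(NC(=O)CCl)cc2)nc(-c2ccccc2)c1-c1ccccc1` gives 42.8% in a functional assay on MCF7 cells (Homo sapiens) for cytotoxicity, read by MTT assay, with a stated time of 24 h, tested at 32 ug/mL (on this read-out lower numbers stand for a weaker effect and higher numbers for a stronger effect at the one concentration tested), the lowest of the three numbers in hand. Compound 2 `Cn1c(-c2ccc(NC(=O)CSc3nc4cc(Cl)ccc4o3)cc2)nc(-c2ccccc2)c1-c1ccccc1` gives 59.7% and compound 3 `Cn1cnnc1SCC(=O)Nc1ccc(-c2nc(-c3ccccc3)c(-c3ccccc3)n2C)cc1` gives 89.2%. Both measured steps from compound 1 exchange the chloro for a heteroaryl sulfanyl: a number 16.9 percentage points higher from compound 1 to compound 2 (beyond the scatter) and a number 46.4 percentage points higher from compound 1 to compound 3 (beyond the scatter); between the two heteroaryl groups, a number 29.5 percentage points higher from compound 2 to compound 3 (beyond the scatter). Compound 4 `Cn1nnnc1SCC(=O)Nc1ccc(-c2nc(-c3ccccc3)c(-c3ccccc3)n2C)cc1` differs from compound 1 by (1-methyl-1H-tetrazol-5-yl)sulfanyl in place of chloro on a saturated chain carbon bound to a carbonyl carbon. The five-membered ring with four hetero atoms stands closest to the 4-methyl-4H-1,2,4-triazol-3-yl of compound 3, so a large rise in this assay is expected, nearer the step to compound 3 than the step to compound 2. For compound 4 an estimate of 80%, range 60% to 95%, is made, meaning an expected a number 37.2 percentage points higher from compound 1 to compound 4 (beyond the scatter).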

Compound 4, a percentage reported as activity, at one concentration (the size of the read-out at that concentration, not a potency): 77.5%
The estimate for compound 4 lay 2.5 percentage points above the measured number; low and high end bracket the measured number.
By their numbers in this assay, from the lowest: compound 1; then compound 2; then compound 4; then compound 3.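

In this assay a third heteroaryl sulfanyl in place of chloro on the saturated chain carbon gives a number 34.7 percentage points higher from compound 1 to compound 4 (beyond the scatter) and thus a further rise at this position. The ring on the sulfur also separates the two nitrogen-rich groups: the exchange to 1-methyl-1H-tetrazol-5-yl gives a number 11.7 percentage points lower from compound 3 to compound 4 (beyond the scatter) and, against the benzoxazole, a number 17.8 percentage points higher from compound 2 to compound 4 (beyond the scatter) for the same group. The number therefore depends on which ring sits on the sulfur, not only on the loss of chloro.

From the compounds shown here alone, whether an amine or a carboxylic acid in place of chloro holds the number stays open. Nothing available explains the order of the four compounds.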